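Series notes: 3-chlorophenyl in place of 2-chlorophenyl

A few compounds are considered here, and "the series" means these few. Any claim that something is new, unique, unknown or untested is made for them only; others in the source may bear on it.

In an ADME assay on NCM460 cells (Homo sapiens) for cytotoxicity, read by MTT assay, with a stated time of 24 h (a higher number here means that more compound is tolerated, a lower number that less compound is tolerated), compound 1 `CC1(C)[C@H]2CC[C@]1(C)N(Cc1cn(-c3ccc(C#N)cc3)nn1)C(=O)C2` gives 8140 nM, compound 2 `CC1(C)[C@H]2CC[C@]1(C)N(Cc1cn(-c3ccccc3C#N)nn1)C(=O)C2` gives 37500 nM and compound 3 `CC1(C)[C@H]2CC[C@]1(C)N(Cc1cn(-c3ccccc3Cl)nn1)C(=O)C2` gives 10800 nM. The value of compound 3 cannot be separated from that of compound 1, as shown by a 1.3-fold higher number from compound 1 to compound 3 (0.12 log units; within the scatter). Compound 2 stands clear of it, as shown by a 3.5-fold lower number from compound 2 to compound 3 (0.54 log units; beyond the scatter).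

The next compound, compound 4 `CC1(C)[C@H]2CC[C@]1(C)N(Cc1cn(-c3cccc(Cl)c3)nn1)C(=O)C2`, has 3-chlorophenyl in place of 2-chlorophenyl on an aromatic nitrogen. Going by the values given here, no measured pair moves a chloro group. The only measured shift of a group around the phenyl ring is a 4.6-fold higher number from compound 1 to compound 2 (0.66 log units; beyond the scatter), with 2-cyanophenyl in place of 4-cyanophenyl. That step is modest and concerns a different group, so it gives weak guidance and no reliable direction in this assay.

The estimated change is small and is expected to stay within the scatter: a 1.1-fold lower number from compound 3 to compound 4 (0.03 log units; within the scatter). For compound 4 the expected value is 10000 nM, with an estimated range of 4500 nM to 24000 nM.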

Compound 4, half-maximal cytotoxic concentration: 8410 nM
For compound 4 the middle estimate is 1.2-fold (0.08 log units) above the measured one; low and high end bracket the measured number.
By their numbers in this assay, from the lowest: compounds 1, 4 and 3 (each within the scatter of the next); then compound 2.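

In this assay, going by these compounds alone, moving the chloro group from 2-chlorophenyl to 3-chlorophenyl on the aromatic nitrogen makes no readable difference (a 1.3-fold lower number from compound 3 to compound 4 (0.11 log units; within the scatter)), so the two chloro placements cannot be told apart, which no earlier pair could test. The 3-chlorophenyl compound also cannot be separated from the 4-cyanophenyl compound (a 1.0-fold higher number from compound 1 to compound 4 (0.01 log units; within the scatter)) but stands clear of the 2-cyanophenyl compound (a 4.5-fold lower number from compound 2 to compound 4 (0.65 log units; beyond the scatter)), which leaves compound 2 as the only one of the four apart from the rest. No measurement shown here accounts for this.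

From the compounds shown here alone, it remains open whether the separation of compound 2 belongs to the nitrile in that placement alone. Going by these compounds, it also remains open how 3-cyanophenyl, or a carboxylic acid or an amine on the phenyl ring, would stand in this assay.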